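Alkoxy versus methyl on the aryl ring of compound 3

A few compounds are considered here, and "the series" means these few. Any claim that something is new, unique, unknown or untested is made for them only; others in the source may bear on it.

Measured so far in an assay on IMR-32 cells for displacement of a labelled ligand from corticotropin-releasing factor receptor 1 (Homo sapiens), read by scintillation counting, with a stated time of 2 h; a lower number here means a stronger inhibitor, a higher number a weaker inhibitor:
compound 1, `CCc1nc(-c2cnc(OC)nc2OC)c(CC)nc1NC(CC)CC`: 17.2 nM
compound 2, `CCc1nc(-c2ccc(OC(F)(F)F)cc2OC)c(CC)nc1NC(CC)CC`: 7.2 nM
compound 3, `CCc1nc(-c2ccc(C)cc2OC)c(CC)nc1NC(CC)CC`: 23.7 nM

Compound 3 gives the highest number of the three; compound 1 lies a short way below it, within the scatter, so no order between those two is claimed. Compound 2 stands clearly lower. Within the data shown here, the one single-point step among the measured compounds is a 3.3-fold higher number from compound 2 to compound 3 (0.52 log units; beyond the scatter), so the move from trifluoromethoxy to methyl on the aryl ring cost potency in this assay.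

Compound 4, `CCOc1ccc(-c2nc(CC)c(NC(CC)CC)nc2CC)c(OC)c1`, is not yet measured. Against compound 3 the difference is ethoxy in place of methyl on an aromatic carbon. This is the reverse kind of move: an oxygen-linked group returns where methyl sat, though ethoxy is not trifluoromethoxy, and compound 1, which carries methoxy groups on a different ring, offers no direct comparison. Among the measured compounds shown here, the only step that bears on it, a 3.3-fold higher number from compound 2 to compound 3 (0.52 log units; beyond the scatter), was modest. A lower number than compound 3 is therefore expected for compound 4, of roughly that size, with the estimated step of a 2.0-fold lower number from compound 3 to compound 4 (0.30 log units; within the scatter). Compound 4 is estimated at 12 nM, in the range 5 nM to 30 nM.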

Compound 4, inhibition constant: 7.8 nM
Beside the measured number, compound 4's estimate is 1.5-fold (0.19 log units) above it, and the stated range covers the measured number.
By their numbers in this assay, from the lowest: compounds 2 and 4 (each within the scatter of the next); then compounds 1 and 3 (each within the scatter of the next).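

At this position, on an aromatic carbon meta to a methoxy group and para to a large group, ethoxy in place of methyl gives a 3.0-fold lower number from compound 3 to compound 4 (0.48 log units; beyond the scatter) in this assay. Read with a 3.3-fold higher number from compound 2 to compound 3 (0.52 log units; beyond the scatter), this shows methyl standing apart from two different oxygen-linked groups rather than from trifluoromethoxy alone, and no compound shown at this position goes against that pattern. Ethyl in place of trifluoromethyl on the oxygen gives a 1.1-fold higher number from compound 2 to compound 4 (0.03 log units; within the scatter), so the two oxygen-linked groups are not separated here, and nothing in hand explains the gap between them and methyl.

Still open, as far as these compounds go, is whether the oxygen or the larger size of the group goes with the lower numbers, a question that a plain ethyl or propyl chain set against a methoxy or hydroxyl group at this position would address. From the compounds shown here alone, how much room the position offers also remains open, and a longer chain such as butoxy, or an amine or a carboxylic acid in the same place, would test its limits.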